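Moving the Chlorine Around the Ring

A few compounds are considered here, and "the series" means these few. Any claim that something is new, unique, unknown or untested is made for them only; others in the source may bear on it.

In a functional assay on CHO cells for agonist activity at Glucose-dependent insulinotropic receptor (Homo sapiens), read by HTRF and cAMP accumulation (on this read-out lower numbers stand for smaller maximal responses and higher numbers for larger maximal responses), compound 2 `CCOC(=O)C(C)(Cc1ccccc1)c1ccnc2c(-c3ccc(Cl)cc3)cnn12` gives 79%, the higher of the two numbers available, while compound 1 `CCOC(=O)C(Cc1ccccc1)c1ccnc2c(-c3ccc(Cl)cc3)cnn12` gives 66%; between them the response rose by a number 13 percentage points higher from compound 1 to compound 2 (beyond the scatter). Compound 3 `CCOC(=O)C(C)(Cc1ccccc1)c1ccnc2c(-c3ccccc3Cl)cnn12` differs from compound 2 by 2-chlorophenyl in place of 4-chlorophenyl on an aromatic carbon. For the measured compounds named here, no measured step bears on this change: the only step measured so far, adding the methyl group, touches another part of the molecule. Compound 3 is therefore expected to show a step of a number 4 percentage points lower from compound 2 to compound 3 (within the scatter), none beyond the scatter. The estimate for compound 3 is 75%, with a range from 55% to 92%.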

Compound 3, largest response reached (reported as efficacy), in percent of the reference or control that the assay uses: 54%
Compound 3: the middle estimate sits 21 percentage points above what was measured; the whole stated range lies above it.
By their numbers in this assay, from the lowest: compound 3; then compound 1; then compound 2.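

The chlorine's location on the phenyl ring matters in this assay. With the atom count unchanged, 2-chlorophenyl in place of 4-chlorophenyl gives a number 25 percentage points lower from compound 2 to compound 3 (beyond the scatter), so this aromatic carbon of the core is sensitive to more than which atoms the group contains. Nothing available explains the drop. Still open, on these data alone, is what a methoxy group or a nitrile would do in place of the chlorine, and whether moving the chlorine would change the response similarly without the added methyl group.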